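The source may report more compounds than this note shows. Statements on the series, on what has been measured and on what is new or still open speak of the compounds shown alone.

Compound 1 `FC(F)(F)c1ccc(/C=C\c2cc3ccccc3nc2Cl)cc1`: 7940 nM
Compound 2 `FC(F)(F)c1cccc(/C=C\c2cc3ccccc3nc2Cl)c1`: 6150 nM
Compound 3 `FC(F)(F)c1cccc(/C=C/c2cc3ccccc3nc2Cl)c1`: 24700 nM

These values come from an ADME assay on 184B5 cells (Homo sapiens) for antiproliferative activity, read by sulforhodamine B assay, with a stated time of 72 h; a higher number here means a weaker inhibitor, a lower number a stronger inhibitor. Compound 2 at 6150 nM lies within the scatter of compound 1 at 7940 nM, while compound 3 stands clearly apart. Compound 4 `FC(F)(F)c1cc(/C=C\c2cc3ccccc3nc2Cl)cc(C(F)(F)F)c1` is compound 2 with one change: trifluoromethyl in place of hydrogen on an aromatic carbon, a trifluoromethyl in place of hydrogen on an aromatic carbon. Among the compounds with values here, the only measured step, a 4.0-fold higher number from compound 2 to compound 3 (0.60 log units; beyond the scatter), is modest and goes with the fact that compounds 2 and 3 differ only in the configuration as drawn. That step touches only the double bond, which compound 4 keeps as drawn in compound 2. Within the data shown here, no measured step adds a trifluoromethyl group, and the direction stays open. The expected step is a 1.2-fold lower number from compound 2 to compound 4 (0.09 log units; within the scatter), with no change beyond the scatter anticipated. For compound 4 the estimated value is 5000 nM, with an expected range of 1800 nM to 15000 nM.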

Compound 4, half-maximal inhibitory concentration: 13700 nM
For compound 4 the middle estimate is 2.7-fold (0.44 log units) below the measured one; the measured number falls inside the stated range.
By their numbers in this assay, from the lowest: compounds 2, 1, 4 and 3 (each within the scatter of the next, the first and the last beyond it).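

In this assay, a second trifluoromethyl in place of hydrogen, meta to the first, gives a 2.2-fold higher number from compound 2 to compound 4 (0.35 log units; beyond the scatter), so the inhibitor becomes weaker. The step is modest, but it shows that a change on this aromatic ring, and not only a change at the double bond, can shift the number beyond the scatter. Nothing available accounts for this shift. Going by these compounds, whether a methoxy group or an amine at this same carbon would also weaken the compound remains open. So does whether a group here could give a stronger inhibitor than compound 2.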